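Chalcone Cytotoxicity in Mouse Macrophages: Compound 1 to Compound 4

A few compounds are considered here, and "the series" means these few. Any claim that something is new, unique, unknown or untested is made for them only; others in the source may bear on it.

The measured compounds and their values:
compound 1 `COc1cc(O)cc(O)c1C(=O)/C=C/c1ccccc1Br`, 14600 nM
compound 2 `C=CCOc1cc(OC)c(C(=O)/C=C/c2cc(OC)c(OC)c(OC)c2)c(OCC=C)c1`, 12000 nM
compound 3 `C=CCOc1cc(OC)c(C(=O)/C=C/c2ccccc2F)c(OCC=C)c1`, 13300 nM

In a toxicity assay on cells (Macrophage, Mus musculus, strain BALB/c) for cytotoxicity, read by MTT assay (on this read-out higher numbers stand for weaker inhibition and lower numbers for stronger inhibition), compound 1 gives 14600 nM, the highest of the three numbers, yet its gap to compound 3 and its gap to compound 2 both lie within the scatter of repeated measurements, so the three compounds cannot be told apart on this read-out. Among the measured compounds shown here, no single step between measured compounds is available, and nothing here shows how a change at the aryl end of the chain moves the number.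

Compound 4 `COc1cc(O)cc(O)c1C(=O)/C=C/c1ccc(O)cc1` arises from compound 1 by one change: 4-hydroxyphenyl in place of 2-bromophenyl on a double-bonded chain carbon bound to a double-bonded chain carbon. For the measured compounds named here, with no measured step to rest on, the expectation leans on the narrow band the three measured compounds occupy. Compound 4 is expected to sit near compound 1, with the step of a 1.2-fold higher number from compound 1 to compound 4 (0.09 log units; within the scatter) estimated to be small and not clearly beyond the scatter. In this assay compound 4 is estimated at 18000 nM, within a range from 8000 nM to 45000 nM, the upper end allowing for weaker inhibition than any compound seen so far.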

Compound 4, half-maximal inhibitory concentration: 21700 nM
For compound 4 the middle estimate is 1.2-fold (0.08 log units) below the measured one, within the range that was stated.
By their numbers in this assay, from the lowest: compounds 2, 3, 1 and 4 (each within the scatter of the next).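

In this assay, among the compounds shown here, the exchange of 2-bromophenyl for 4-hydroxyphenyl on a double-bonded chain carbon bound to a double-bonded chain carbon gives the first single-place comparison in this set, with a 1.5-fold higher number from compound 1 to compound 4 (0.17 log units; within the scatter) on the shared core. This exchange replaces a ring carrying bromine with one carrying oxygen, and it adds one hydrogen-bond donor and one hydrogen-bond acceptor by count, yet it does not separate the two compounds on this read-out, so this single change at this place gives no readable shift in cytotoxicity. No measurement at hand bears on the result.

The two groups differ both in the atom they carry and in where their names place it, so the compounds shown cannot assign the step to either difference, and they leave open whether any change at this place can move the number beyond the scatter. A phenyl ring carrying an amine or a carboxylic acid at this same place would test that question, as would a single-place comparison linking the shared core of compound 1 to the core of compound 2 or compound 3.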